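The compounds below may be only part of what the source reports. "The series", "measured", "known", "first", "only" and "open" are said of these compounds alone.

Measured compounds:
compound 1, `CO/N=c1\[nH]cnc2c1[n+](C/C=C(\C)CC/C=C(/C)CCC=C(C)C)cn2C`: 28700 nM
compound 2, `CC(C)=CCC/C(C)=C\CC/C(C)=C/C[n+]1cn(C)c2nc[nH]/c(=N\OCc3ccccc3)c21`: 25200 nM
compound 3, `CO/N=c1\[nH]cnc2c1[n+](C/C=C(\C)CCCC(C)CCCC(C)CCCC(C)C)cn2C`: 16900 nM

All three values come from a functional assay on ACHN cells (Homo sapiens) for cytotoxicity; on this read-out higher numbers stand for weaker inhibition and lower numbers for stronger inhibition. Compound 2 is compound 1 with phenyl in place of hydrogen on a saturated chain carbon bound to an oxygen, and this change made the step of a 1.1-fold lower number from compound 1 to compound 2 (0.06 log units; within the scatter). Compound 3 shares the same core as compound 1 on the charged side but carries a different chain; the difference between the two cores is not broken down here. Compound 3 and compound 2 sit within the scatter of each other, as do compound 3 and compound 1, so no order among the three is claimed.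

Compound 4, `C/C(=C\C[n+]1cn(C)c2nc[nH]/c(=N\OCc3ccccc3)c21)CCCC(C)CCCC(C)CCCC(C)C`, is not yet measured. It stands to compound 3 as compound 2 stands to compound 1: phenyl in place of hydrogen on a saturated chain carbon bound to an oxygen. The place is described in the same words in both cases, so this is the same change. Since the earlier step of a 1.1-fold lower number from compound 1 to compound 2 (0.06 log units; within the scatter) stayed within the scatter, the step expected from compound 3 to compound 4 is likewise small, a 1.1-fold lower number from compound 3 to compound 4 (0.05 log units; within the scatter), because compound 1 to compound 2 gave a 1.1-fold lower number from compound 1 to compound 2 (0.06 log units; within the scatter). Compound 4 is therefore estimated at 15000 nM in this assay, expected to lie between 7000 nM and 32000 nM.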

Compound 4, half-maximal inhibitory concentration: 20500 nM
The estimate for compound 4 lay 1.4-fold (0.14 log units) below the measured number; low and high end bracket the measured number.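

In this assay, methoxy to benzyloxy on the core of compound 3 gave a 1.2-fold higher number from compound 3 to compound 4 (0.08 log units; within the scatter). Set beside the earlier step, the change carries over between these two cores with no readable difference: the same change on two cores in this assay, a 1.1-fold lower number (0.06 log units; within the scatter) from compound 1 to compound 2 and a 1.2-fold higher number (0.08 log units; within the scatter) from compound 3 to compound 4, 1.4-fold (0.14 log units) apart, within the scatter of two such steps. Among these compounds, this shows only that the change stays within the scatter on both cores; it shows neither a gain nor a loss from the change on either core, and two pairs in one cell assay say nothing about further cores.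

Left open is whether a group other than phenyl at this place, such as an amine, a carboxylic acid or a longer chain, would shift the number beyond the scatter. Also open, from the compounds shown here alone, is whether the same holds on cells other than those of this assay.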